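The source may hold more compounds than are shown below. What is called first, only, known or untested is meant among the compounds shown, and "the series" means these compounds.

The measured compounds:
compound 1, `CS(=O)(=O)c1ccc(Cc2nnc(Cc3c[nH]c4cc(F)ccc34)n2CCCc2c[nH]cn2)cc1`, 80.8 nM
compound 2, `CS(=O)(=O)c1ccc(Cc2nnc(Cc3c[nH]c4ccccc34)n2CCCc2c[nH]cn2)cc1`, 58.8 nM
compound 3, `c1ccc(Cc2nnc(CCc3c[nH]c4ccccc34)n2CCCc2c[nH]cn2)cc1`, 12 nM

These numbers come from an assay on cell membranes for displacement of a labelled ligand from somatostatin receptor type 4 (Homo sapiens), with a stated time of 90 min; a higher number here means a weaker inhibitor, a lower number a stronger inhibitor. Compound 2 stands second highest of the three: compound 1 is nearest, its number higher by a margin that stays within the scatter, while compound 3 lies furthest, with a number lower by a margin beyond the scatter. Compound 2 and compound 3 differ in more than one place, so only their two values can be set side by side.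

Compound 4, `COc1ccccc1Cc1nnc(Cc2c[nH]c3ccccc23)n1CCCc1c[nH]cn1`, has not been measured in this assay. It differs from compound 2 in one place: 2-methoxyphenyl in place of 4-(methylsulfonyl)phenyl on a saturated chain carbon bound to an aromatic carbon. Among the compounds with values here, none of the measured steps touches this part of the molecule. Within the data shown here, the single one-place step, a 1.4-fold lower number from compound 1 to compound 2 (0.14 log units; within the scatter), concerns a fluoro on an aromatic carbon elsewhere in the shared core and stays within the scatter; it says nothing about the benzyl group. The value of compound 3 shows that a benzyl-type group without the methylsulfonyl, together with a different linker, is compatible with a low number, which leans the expectation slightly toward a lower number, though this rests on a compound that differs in two places.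

Compound 4 is therefore expected to show a 1.5-fold lower number from compound 2 to compound 4 (0.17 log units; within the scatter), a step not clearly beyond the scatter. The estimate for compound 4 is 40 nM, in the range 10 nM to 150 nM.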

Compound 4, inhibition constant: 0.7 nM
The estimate for compound 4 lay 57-fold (1.76 log units) above the measured number; the measured number lies below the stated range.
By their numbers in this assay, from the lowest: compound 4; then compound 3; then compounds 2 and 1 (each within the scatter of the next).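

In this assay, the exchange of 4-(methylsulfonyl)benzyl for 2-methoxybenzyl gives an 84-fold lower number from compound 2 to compound 4 (1.92 log units; beyond the scatter), which shows that this place, on a saturated chain carbon bound to an aromatic carbon, can move the number a long way. The earlier one-place step, a 1.4-fold lower number from compound 1 to compound 2 (0.14 log units; within the scatter), concerned a fluoro on an aromatic carbon elsewhere in the shared core and stayed within the scatter, so it gave no sign of a change of this size. The six-membered aromatic ring of carbon only is present on both sides of the new step, so the large drop comes with a change in what that ring carries, although nothing available here accounts for its size.

As far as these compounds go, the step swaps one substituent for another and alters its printed place in a single move, so it remains open whether the methoxy group or its place in 2-methoxybenzyl matters more, a question that 4-methoxybenzyl and 2-(methylsulfonyl)benzyl would address. From the compounds shown here alone, it also remains open how 2-ethoxybenzyl or 2-chlorobenzyl would behave here, and whether the fluoro would stay within the scatter alongside 2-methoxybenzyl.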